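Swapping a propyl chain for an ethylphenyl ring on the amide

The source may report more compounds than this note shows. Statements on the series, on what has been measured and on what is new or still open speak of the compounds shown alone.

Within the data shown here, the two compounds measured so far are compound 1, `CN(C)c1ccc(C(=O)Nc2cccc(NC(=O)COc3ccc4c(c3)NC(=O)CC4)c2)cc1`, and compound 2, `CCCC(=O)Nc1cccc(NC(=O)COc2ccc3c(=O)ccoc3c2)c1`. In an assay on isolated protein for inhibition of Rho-associated protein kinase 2 (Homo sapiens), read by scintillation counting, radiometric assay and 33P incorporation, with a stated time of 40 min, in the presence of a further agent that is not named here (on this read-out lower numbers stand for stronger inhibition and higher numbers for weaker inhibition), compound 1 gives 3140 nM, while compound 2 gives 176 nM. Compound 2 therefore stands lowest of the two numbers, and its nearest neighbour, compound 1, sits well beyond the usual scatter; the two differ in more than one place, so the gap cannot be tied to a single change. Compound 3, `CCc1ccc(C(=O)Nc2cccc(NC(=O)COc3ccc4c(=O)ccoc4c3)c2)cc1`, keeps the core of compound 2 and changes only the amide: 4-ethylphenyl in place of propyl on a carbonyl carbon. Among the measured compounds shown here, with no measured pair isolating such a change, the step of a 1.1-fold higher number from compound 2 to compound 3 (0.06 log units; within the scatter) is expected to stay within the scatter, in no clear direction. Compound 3 is accordingly estimated at 200 nM, with a likely range from 50 nM to 800 nM.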

Compound 3, half-maximal inhibitory concentration: 24 nM
Compound 3: the middle estimate sits 8.3-fold (0.92 log units) above what was measured; the measured number lies below the stated range.
By their numbers in this assay, from the lowest: compound 3; then compound 2; then compound 1.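

The amide position of this core is sensitive to the group on the carbonyl carbon: in this assay the swap of propyl for 4-ethylphenyl gives a 7.3-fold lower number from compound 2 to compound 3 (0.87 log units; beyond the scatter) and lies beyond the scatter. Among these compounds, this is the first step here that can be tied to a single change, and it shows that a larger group carrying a six-membered aromatic ring is tolerated at this place and goes with stronger inhibition. Nothing measured here accounts for the drop.

The compounds shown cannot separate the contribution of the ring from that of its ethyl group, and an unsubstituted phenyl would speak to that. Nor can they tell whether the ring is needed at all, which a longer straight chain such as hexyl would test.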